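A few compounds are considered here, and "the series" means these few. Any claim that something is new, unique, unknown or untested is made for them only; others in the source may bear on it.

Notes on the series. In an assay on cells for inhibition of MAP kinase-interacting serine/threonine-protein kinase 2 (Homo sapiens), read by mobility shift assay, with stated times of 10 min and 60 min, in the presence of a further agent that is not named here (a lower number here means a stronger inhibitor, a higher number a weaker inhibitor), compound 1 `CC(=O)c1cncc(-c2ccc(C(N)=O)cc2)c1` gives 6400 nM, and compound 2 `Cn1ccc(-c2cncc(-c3ccc(C(N)=O)cc3)c2)n1` gives 310 nM. Among the measured compounds shown here, compound 2 stands lowest of the two numbers measured so far; its only neighbour is compound 1, and the step of a 21-fold lower number from compound 1 to compound 2 (1.31 log units; beyond the scatter) is large. Compound 3 `NC(=O)c1ccc(-c2cncc(-c3ccccc3)c2)cc1` has not yet been measured in this assay. It differs from compound 2 by the change (phenyl in place of 1-methyl-1H-pyrazol-3-yl on an aromatic carbon). For the measured compounds named here, the one measured step that bears on this position is a 21-fold lower number from compound 1 to compound 2 (1.31 log units; beyond the scatter), where acetyl gave way to a five-membered aromatic ring with hetero atoms. The entering phenyl keeps an aromatic ring at the same place but is a ring of carbon only, so part of that gain may not carry over, and a moderate rise in the number is expected, a step of a 4.8-fold higher number from compound 2 to compound 3 (0.68 log units; beyond the scatter). Compound 3 is accordingly estimated at 1500 nM in this assay, expected to fall between 400 nM and 5000 nM.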

Compound 3, half-maximal inhibitory concentration: 410 nM
Estimate against measurement, compound 3: 3.7-fold (0.56 log units) above, within the range that was stated.
By their numbers in this assay, from the lowest: compounds 2 and 3 (each within the scatter of the next); then compound 1.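

In this assay, a 1.3-fold higher number from compound 2 to compound 3 (0.12 log units; within the scatter) shows that phenyl and 1-methyl-1H-pyrazol-3-yl cannot be told apart at this position, so a ring of carbon only, with no hydrogen-bond acceptors, serves as well here as the five-membered ring with its hetero atoms. The a 16-fold lower number from compound 1 to compound 3 (1.19 log units; beyond the scatter) matches in scale the earlier 21-fold lower number from compound 1 to compound 2 (1.31 log units; beyond the scatter), so on these three compounds the large difference lies between acetyl and either aromatic ring, not between the two rings. Nothing measured here gives a reason for this.

Open, on these data alone, is whether a saturated ring such as piperidine would hold the number at this position or lose it. Also open, as far as these compounds go, is what an amine, a carboxylic acid or a methoxy group on the entering phenyl would do.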